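This account rests on a few compounds, and the source may have more. Where it says the series, first, only, none or still open, it means among the compounds named here.

Values so far in an ADME assay on MDCK cells (Canis lupus familiaris) for cytotoxicity, read by MTT assay, with a stated time of 24 h (a higher number here means that more compound is tolerated, a lower number that less compound is tolerated), are as follows
Compound 1 `Cc1cc(CNS(=O)(=O)c2ccc([N+](=O)[O-])cc2)c(C)o1` gives > 152000 nM (a limit)
Compound 2 `Cc1cc(CNS(=O)(=O)c2ccc(F)cc2)c(C)o1` gives 138000 nM
Compound 3 `Cc1cc(CNS(=O)(=O)c2ccc(Cl)cc2)c(C)o1` gives 55700 nM

Compound 1 stands at the limit of > 152000 nM in this assay, at which 1 of the 3 values shown sits, and that reading is a limit, not a number. Compound 4 `O=[N+]([O-])c1ccc(S(=O)(=O)NCc2ccc(Cl)s2)cc1` keeps the nitro group of compound 1 and exchanges one group: 5-chlorothiophen-2-yl in place of 2,5-dimethylfuran-3-yl on a saturated chain carbon bound to a sulfonamide nitrogen. For the measured compounds named here, no measured step makes this exchange, so the guidance is indirect. The closest hints come from the two steps that bring in chloro on an aromatic carbon: an at least 2.7-fold lower number from compound 1 to compound 3 (0.43 log units; beyond the scatter) and a 2.5-fold lower number from compound 2 to compound 3 (0.39 log units; beyond the scatter). Both lie beyond the scatter and both lower the number. By contrast, an at least 1.1-fold lower number from compound 1 to compound 2 (0.04 log units; that floor lies within the scatter) has a floor within the scatter. Since 5-chlorothiophen-2-yl also carries chlorine, a modest fall in this assay is expected, with the estimated step being an at least 2.5-fold lower number from compound 1 to compound 4 (0.40 log units; beyond the scatter) in size. For compound 4 the estimated value is 60000 nM with an expected range from 20000 nM to 170000 nM as its bounds.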

Compound 4, half-maximal cytotoxic concentration: 128000 nM
For compound 4 the middle estimate is 2.1-fold (0.33 log units) below the measured one, and the stated range covers the measured number.
By their numbers in this assay, from the lowest: compound 3; then compounds 4 and 2 (each within the scatter of the next). At a limit, above all of these: compound 1.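

The earlier compounds all carried 2,5-dimethylfuran-3-yl and differed only on an aromatic carbon, so this is the only step shown on a saturated chain carbon bound to a sulfonamide nitrogen. In this assay, the step to 5-chlorothiophen-2-yl is an at least 1.1-fold lower number from compound 1 to compound 4 (0.07 log units; that floor lies within the scatter), whereas chloro in place of nitro on an aromatic carbon gave an at least 2.7-fold lower number from compound 1 to compound 3 (0.43 log units; beyond the scatter). The full size of the new step cannot be read, since the reading for compound 1 is a limit: the limit of > 152000 nM in this assay, at which 1 of the 4 values shown sits.

The compounds shown leave open whether the chlorine or the thiophene ring accounts for any part of this step, which a plain thiophen-2-yl group could separate. They also leave open how this place responds to a group of another kind, such as an aminomethyl group.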